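The source may hold more compounds than are shown below. What is called first, only, known or untested is meant among the compounds shown, and "the series" means these compounds.

Measured compounds:
compound 1, `CCCN(CCC)c1nc(C(F)(F)F)ccc1CNC(=O)C(C)c1ccc(NS(C)(=O)=O)c(F)c1` — in a functional assay on CHO-K1 cells for antagonist activity at transient receptor potential cation channel subfamily V member 1 (Homo sapiens), read by FLIPR (on this read-out higher numbers stand for weaker inhibition and lower numbers for stronger inhibition), compound 1 gives 14.7 nM.
compound 2, `CCCCN(C)c1nc(C(F)(F)F)ccc1CNC(=O)C(C)c1ccc(NS(C)(=O)=O)c(F)c1` — in this assay compound 2 gives 21.3 nM.

For the measured compounds named here, compound 2 has the highest of the two numbers seen, and its only neighbour is compound 1: the step of a 1.4-fold higher number from compound 1 to compound 2 (0.16 log units; within the scatter) lies within the scatter, so the two compounds cannot be told apart on this read-out.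

Compound 3, `CC(C(=O)NCc1ccc(C(F)(F)F)nc1N(C)c1ccccc1)c1ccc(NS(C)(=O)=O)c(F)c1`, has not yet been measured. It differs from compound 2 in one place: phenyl in place of butyl on a nitrogen on an aromatic ring. Going by the values given here, the one measured step, from compound 1 to compound 2, reshuffled the chains on that same nitrogen and changed the number only within the scatter. Among the compounds with values here, it says nothing direct about trading a chain for a ring, so there is no measured step that bears on this change. Within the data shown here, the expectation for compound 3 therefore rests on the shared core, which kept its potency through the one change seen, with a wide range to reflect the missing precedent. Compound 3 is expected to give about 30 nM, between 8 nM and 120 nM, which corresponds to an estimated step of a 1.4-fold higher number from compound 2 to compound 3 (0.15 log units; within the scatter).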

Compound 3, half-maximal inhibitory concentration: 57.4 nM
Compound 3: the middle estimate sits 1.9-fold (0.28 log units) below what was measured; the measured number falls inside the stated range.
By their numbers in this assay, from the lowest: compounds 1 and 2 (each within the scatter of the next); then compound 3.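

On this nitrogen on an aromatic ring, replacing butyl with phenyl produces a change beyond the scatter in this assay (a 2.7-fold higher number from compound 2 to compound 3 (0.43 log units; beyond the scatter)), and the comparison of methyl(phenyl)amino with dipropylamino points the same way (a 3.9-fold higher number from compound 1 to compound 3 (0.59 log units; beyond the scatter)). Among the three compounds, the substituents on this nitrogen therefore do affect inhibition, although exchanging dipropylamino for butyl(methyl)amino gave only a step within the scatter (a 1.4-fold higher number from compound 1 to compound 2 (0.16 log units; within the scatter)), and both steps to compound 3 are modest, so an aromatic ring of six carbons is accepted here at some cost rather than ending the activity. No supporting measurement is available to explain why compound 3 gives the highest number of the three.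

The compounds shown leave open whether the higher number goes with the aromatic ring in particular or with any ring in place of a chain, a question that a cyclohexyl group on the same nitrogen could help to settle. They also leave open how a benzyl group, or a phenyl ring carrying a fluorine or a methoxy group, would behave at this position.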